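Methyl on the amide nitrogen in two different cores

This account rests on a few compounds, and the source may have more. Where it says the series, first, only, none or still open, it means among the compounds named here.

Compound 1 `O=C(Nc1nc(-c2cccc(Br)c2)cs1)c1ccccc1` and compound 3 `CN(C(=O)c1ccccc1)c1nc(-c2cccc(Br)c2)cs1` share one core, while compound 2 `COc1cc(-c2csc(NC(=O)c3ccccc3)n2)cc(OC)c1OC` carries another; the difference between the two cores is not broken down here. In a functional assay on MDA-MB-231 cells (Homo sapiens), read by microscopy and transwell migration, with a stated time of 24 h (a lower number here means a stronger inhibitor, a higher number a weaker inhibitor), compound 1 gives 10000 nM and compound 3 gives 437 nM. Compound 2 reaches only a limit of this assay, > 50000 nM, which the limit of > 50000 nM in this assay, at which 1 of the 3 values shown sits, reflects. The change from compound 1 to compound 3 is methyl in place of hydrogen on an amide-type nitrogen, and it brought a 23-fold lower number from compound 1 to compound 3 (1.36 log units; beyond the scatter). Compound 4 `COc1cc(-c2csc(N(C)C(=O)c3ccccc3)n2)cc(OC)c1OC` is not yet measured; it arises from compound 2 by the same kind of change, (methyl in place of hydrogen on an amide-type nitrogen). Because the change gave a 23-fold lower number from compound 1 to compound 3 (1.36 log units; beyond the scatter), a step of roughly an at least 8.3-fold lower number from compound 2 to compound 4 (0.92 log units; beyond the scatter) is expected from compound 2, though the starting point is only a limit. Compound 4 is therefore estimated at 6000 nM, within 1200 nM to 50000 nM.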

Compound 4, half-maximal inhibitory concentration: 10000 nM
Compound 4: middle estimate off by 1.7-fold (0.22 log units), on the low side; low and high end bracket the measured number.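

In this assay, methyl in place of hydrogen on an amide-type nitrogen also lowers the number on the second core, with an at least 5.0-fold lower number from compound 2 to compound 4 (0.69 log units; beyond the scatter), so the direction of the change carries across these two cores. Compound 2 gives > 50000 nM, which is a limit of the assay and not a number. The true size of this second step therefore stays unknown, and two cores cannot show that the change would carry to any other core: the same change on two cores in this assay, a 23-fold lower number (1.36 log units; beyond the scatter) from compound 1 to compound 3 and an at least 5.0-fold lower number (0.69 log units; beyond the scatter) from compound 2 to compound 4; the limit leaves it open whether they differ

Still open, from the compounds shown here alone, is whether an ethyl group or a longer chain on the same nitrogen would act as methyl does. Also open, going by these compounds, is how the step would run on a core carrying an amine or a carboxylic acid.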